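Swapping an oxy link for an amino link

A few compounds are considered here, and "the series" means these few. Any claim that something is new, unique, unknown or untested is made for them only; others in the source may bear on it.

Among the compounds with values here, in a functional assay on SK-MEL-2 cells (Homo sapiens) for antiproliferative activity, read by sulforhodamine B assay, with a stated time of 48 h (a lower number here means a stronger inhibitor, a higher number a weaker inhibitor), compound 1 (`C/C=C(\C)C(=O)O[C@H]1C=CC(=O)O[C@H]1CCC(=O)[C@H](C)O`) gives 24000 nM and compound 2 (`C/C=C(\C)C(=O)O[C@H]1C=CC(=O)O[C@H]1COC(=O)[C@H](C)O`) gives 13000 nM as the only two numbers so far. Within the data shown here, the measured step between them reads a 1.8-fold lower number from compound 1 to compound 2 (0.27 log units; within the scatter) and so compound 2 cannot be told apart from its one neighbour. Compound 3 (`C/C=C(\C)C(=O)O[C@H]1C=CC(=O)O[C@H]1CNC(=O)[C@H](C)O`) is still unmeasured and shares the core of compound 2. Its change is ((1-hydroxyethyl)carbonyl)amino in place of ((1-hydroxyethyl)carbonyl)oxy on a saturated chain carbon bound to a saturated ring carbon. Among the measured compounds shown here, only one measured step bears on this. It sits at the same place, where ((1-hydroxyethyl)carbonyl)oxy stands in place of ((1-hydroxyethyl)carbonyl)methyl, and its size (a 1.8-fold lower number from compound 1 to compound 2 (0.27 log units; within the scatter)) is small. For the measured compounds named here, no measured compound yet carries the amino link, so this single step is thin evidence. On that evidence, no step beyond the scatter is expected in this assay for this exchange. The estimated step (a 1.2-fold higher number from compound 2 to compound 3 (0.09 log units; within the scatter)) is correspondingly small. Compound 3 is estimated at 16000 nM with an expected range of 6000 nM to 42000 nM in this measurement.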

Compound 3, half-maximal inhibitory concentration: 28000 nM
For compound 3 the middle estimate is 1.8-fold (0.24 log units) below the measured one; the measured number falls inside the stated range.
By their numbers in this assay, from the lowest: compounds 2, 1 and 3 (each within the scatter of the next, the first and the last beyond it).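

In this assay, this position now shows its first step beyond the usual scatter: ((1-hydroxyethyl)carbonyl)amino in place of ((1-hydroxyethyl)carbonyl)oxy on a saturated chain carbon bound to a saturated ring carbon gives a 2.2-fold higher number from compound 2 to compound 3 (0.33 log units; beyond the scatter) as a modest change, so the choice between these two links can register here, which the earlier pair could not show. Set against the ((1-hydroxyethyl)carbonyl)methyl group, the amino link gives a 1.2-fold higher number from compound 1 to compound 3 (0.07 log units; within the scatter) and stays within the scatter, so the methylene and amino links cannot be told apart, and only the pair of oxy and amino links separates at all. No measured evidence is available to explain why these two links part while the others do not.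

The compounds shown leave open how a sulfonamide or a urea at this place would compare with these three links. They also leave open whether a carboxylic acid or a longer chain in place of the 1-hydroxyethyl end would widen this modest gap or remove it.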